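A few compounds are considered here, and "the series" means these few. Any claim that something is new, unique, unknown or untested is made for them only; others in the source may bear on it.

Of the compounds shown here, three sharing one core have been tested in a functional assay on HepG2 cells (Homo sapiens) for cytotoxicity, read by MTT assay, with a stated time of 48 h; on this read-out lower numbers stand for stronger inhibition and higher numbers for weaker inhibition. Compound 1 `O=C(CSCc1nc2cc([N+](=O)[O-])ccc2[nH]1)c1ccc(Cl)cc1` gives 2650 nM in this assay. Compound 2 `O=C(CSCc1nc2cc([N+](=O)[O-])ccc2[nH]1)c1ccc(Br)cc1` gives 2010 nM in this assay. The step of a 1.3-fold lower number from compound 1 to compound 2 (0.12 log units; within the scatter) stays within the scatter. Compound 3 `CCOC(=O)CSCc1nc2cc([N+](=O)[O-])ccc2[nH]1` reaches only the limit of this assay, > 100000 nM, and no number is known for it. Compound 3 therefore stands apart from compound 1 and compound 2, which both return measured numbers. The steps of an at least 37-fold higher number from compound 1 to compound 3 (1.57 log units; beyond the scatter) and an at least 49-fold higher number from compound 2 to compound 3 (1.69 log units; beyond the scatter) are large: in each, an aryl ketone gives way to an ethoxy group on the carbonyl carbon, and the number climbs to the boundary noted at the limit of > 100000 nM in this assay, at which 1 of the 3 values shown sits.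

Compound 4 `N#CCSCc1nc2cc([N+](=O)[O-])ccc2[nH]1` differs from compound 3 by cyano in place of ethoxycarbonyl on a saturated chain carbon bound to a sulfur. Among the measured compounds shown here, no measured step covers this change. What the measured steps show is that the aryl ketone accompanies the numbers of compound 1 and compound 2, and compound 4, like compound 3, carries no aryl ketone. Compound 4 is therefore expected to sit near the limit as well, at an estimated 100000 nM, with a range from 25000 nM to 400000 nM. The step of a number no higher from compound 3 to compound 4 (the limit leaves the size open) is expected to be none beyond the scatter.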

Compound 4, half-maximal inhibitory concentration: 30600 nM
Compound 4: middle estimate off by 3.3-fold (0.51 log units), on the high side; measured number inside the range.
By their numbers in this assay, from the lowest: compounds 2 and 1 (each within the scatter of the next); then compound 4. At a limit, above all of these: compound 3.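

In this assay, the saturated chain carbon bound to a sulfur proves responsive even with no aryl ketone present: cyano in place of ethoxycarbonyl brings the read-out back to a measured number (an at least 3.2-fold lower number from compound 3 to compound 4 (0.51 log units; beyond the scatter)). Among the compounds shown here, an aryl ketone is therefore not the only group at this place that gives a measured number: compound 4 gives 30600 nM, while compound 1 gives 2650 nM and compound 2 gives 2010 nM. On these data alone, compound 3 holds only a limit and not a number, so the full size of the step remains unknown: the limit of > 100000 nM in this assay, at which 1 of the 4 values shown sits.

The compounds shown leave open whether the change in the number follows the nitrile itself or the smaller group, with ethoxycarbonyl at 5 heavy atoms and cyano at 2, and a carboxylic acid, a primary amide or a simple acetyl group at this place would separate those readings. They also leave open how an unsubstituted phenyl ketone or a longer chain ending in a nitrile would read on the same core.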